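The source may report more compounds than this note shows. Statements on the series, on what has been measured and on what is new or still open speak of the compounds shown alone.

Compound 3 `Cn1nc(-c2ccc(OCC3CCNCC3)c(F)c2)c2cnc(N)nc21` stands second highest of the three numbers in an assay on THP-1 cells for antagonist activity at Toll-like receptor 8 (Homo sapiens); a higher number here means a weaker inhibitor, a lower number a stronger inhibitor: its value, 60 nM, sits within the scatter of compound 1 `Cn1nc(-c2ccc(OCC34CCC(O)(CC3)CC4)c(F)c2)c2cnc(N)nc21`, which gives 75 nM, while compound 2 `Cn1nc(-c2ccc(OC[C@H]3CC[C@@H](N)CC3)c(F)c2)c2cnc(N)nc21`, which gives 20 nM, lies clearly lower, as the step of a 3.0-fold higher number from compound 2 to compound 3 (0.48 log units; beyond the scatter) shows. Compound 4 `Cn1nc(-c2ccc(OCC3CC4(CNC4)C3)c(F)c2)c2cnc(N)nc21` is obtained from compound 3 by the change (a group of 7 heavy atoms (6 carbon, 1 nitrogen; one four-membered non-aromatic ring of carbon only, one four-membered non-aromatic ring with 1 hetero atom) in place of a group of 6 heavy atoms (5 carbon, 1 nitrogen; one six-membered non-aromatic ring with 1 hetero atom), on a saturated chain carbon bound to an oxygen on an aromatic ring). The measured steps that bear on this position are a 3.8-fold lower number from compound 1 to compound 2 (0.57 log units; beyond the scatter), a 1.3-fold lower number from compound 1 to compound 3 (0.10 log units; within the scatter) and a 3.0-fold higher number from compound 2 to compound 3 (0.48 log units; beyond the scatter): all three swap the group on the saturated chain carbon bound to the oxygen on the aromatic ring, and none moves the number by more than a modest amount. A further swap of this kind, which keeps one hydrogen-bond donor and one hydrogen-bond acceptor, is therefore expected to stay within that same narrow band in this assay, with no clear direction. Compound 4 is expected to give 50 nM, estimated between 20 nM and 150 nM, which would mean a step of a 1.2-fold lower number from compound 3 to compound 4 (0.08 log units; within the scatter).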

Compound 4, half-maximal inhibitory concentration: 10 nM
For compound 4 the middle estimate is 5.0-fold (0.70 log units) above the measured one; the whole stated range lies above it.
By their numbers in this assay, from the lowest: compounds 4 and 2 (each within the scatter of the next); then compounds 3 and 1 (each within the scatter of the next).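

In this assay, the swap of piperidin-4-yl for the group with two four-membered rings, on the saturated chain carbon bound to an oxygen on an aromatic ring, gives a 6.0-fold lower number from compound 3 to compound 4 (0.78 log units; beyond the scatter), although the counted hydrogen-bond donors and acceptors and the net charge stay the same, so matching these counts does not hold the number in place at this position. The step of a 2.0-fold lower number from compound 2 to compound 4 (0.30 log units; within the scatter) puts this group level with 4-aminocyclohexyl, while a 7.5-fold lower number from compound 1 to compound 4 (0.88 log units; beyond the scatter) is the widest step in the set, which shows that a non-aromatic ring of carbon only is not needed to reach the low end of the range. Nothing available explains why this change moves the number as it does.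

The compounds shown leave open whether a single azetidine ring or a piperazine ring at this place would also give a low number. They also leave open how a morpholine ring or an open-chain amine would compare.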